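This account rests on a few compounds, and the source may have more. Where it says the series, first, only, none or still open, it means among the compounds named here.

Within the data shown here, in a functional assay on B16-F10 cells (Mus musculus) for inhibition, read by MTT assay, with a stated time of 72 h (on this read-out higher numbers stand for weaker inhibition of growth and lower numbers for stronger inhibition of growth), compound 1 (`CC(C)=CC(=O)NC(=N)N`) gives 92800 nM and compound 2 (`C=C1CCCC(C)(C)[C@@H]1CC/C(C)=C/C(=O)NC(=N)NC(=O)C=C(C)C`) gives 9600 nM as the lowest number so far. Compound 3 (`CC(C)=CC(=O)NC(=N)NC(=O)C=C(C)C`) sits between them at 21300 nM and stands beyond the scatter from both. Compound 4 (`CC(C)=CCC/C(C)=C/C(=O)NC(=N)NC(=O)C=C(C)C`) carries 3-methylbut-2-en-1-yl in place of hydrogen on a saturated chain carbon bound to a double-bonded chain carbon. Among the measured compounds shown here, no measured pair shows this change alone. For the measured compounds named here, the only guide is compound 2, which carries a larger group and stands at 9600 nM against the higher number of compound 3. A modest move toward stronger inhibition of growth, about the size of the scatter, is therefore expected, estimated as a 1.9-fold lower number from compound 3 to compound 4 (0.29 log units; within the scatter) in all. For compound 4 the estimated value is 11000 nM (expected range 5500 nM to 23000 nM).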

Compound 4, concentration for 50% growth inhibition: 25000 nM
The estimate for compound 4 lay 2.3-fold (0.36 log units) below the measured number; the whole stated range lies below it.
By their numbers in this assay, from the lowest: compound 2; then compounds 3 and 4 (each within the scatter of the next); then compound 1.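

In this assay, among these compounds, the only step that isolates one change, a 1.2-fold higher number from compound 3 to compound 4 (0.07 log units; within the scatter), shows that 3-methylbut-2-en-1-yl on a saturated chain carbon bound to a double-bonded chain carbon gives a number within the scatter of the one with hydrogen there. At this position, then, this open chain does not separate the two compounds on this read-out. Nothing available accounts for this result.

Going by these compounds, whether a methyl, an amine or a carboxylic acid on this same carbon would give a different number stays open. So does whether a longer chain there would move the number beyond the scatter.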